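Methoxy removal on three chalcone-type pyrazoles: a small step

This account rests on a few compounds, and the source may have more. Where it says the series, first, only, none or still open, it means among the compounds named here.

Measured compounds:
compound 1 `COc1ccc(-c2cc(/C=C/C(=O)c3ccc(N)cc3)[nH]n2)cc1` 96%
compound 2 `COc1ccc(-c2cc(/C=C/C(=O)c3ccc(N)cc3)[nH]n2)cc1OC` 92%
compound 3 `COc1cc(C(=O)/C=C/c2cc(-c3cc(OC)c(OC)c(OC)c3)n[nH]2)cc(OC)c1OC` 105%

The three compounds were tested in a functional assay on BT-549 cells (Homo sapiens) for cytotoxicity, read by sulforhodamine B assay, with a stated time of 48 h, tested at 0.1 uM; a higher number here means a weaker effect of the compound at the concentration tested, a lower number a stronger effect. Compound 1 gives 96%, compound 2 gives 92%, and compound 3 gives 105%. Between compound 2 and compound 1 the only structural difference is hydrogen in place of methoxy on an aromatic carbon and the step is a number 4 percentage points higher from compound 2 to compound 1 (within the scatter). Compound 3 stands highest of the three, with compound 1 nearest and within the scatter and compound 2 furthest and beyond the scatter. How the core of compound 3 differs from that of compound 2 is not broken down here.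

Compound 4 `COc1ccc(-c2cc(/C=C/C(=O)c3cc(OC)c(OC)c(OC)c3)[nH]n2)cc1OC` has not yet been measured in this assay. It differs from compound 3 by hydrogen in place of methoxy on an aromatic carbon. Among the compounds with values here, this is the same kind of change as the one from compound 2 to compound 1, though the surroundings are not the same word for word: in compound 3 the carbon that loses its methoxy is also meta to a methoxy group, which is not the case in compound 2.

Because a number 4 percentage points higher from compound 2 to compound 1 (within the scatter) is within the scatter, compound 4 is expected to give a result close to that of compound 3 in this assay, with a step of about a number 1 percentage points lower from compound 3 to compound 4 (within the scatter). The estimate for compound 4 is 104%, expected between 90% and 118%.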

Compound 4, a percentage reported as activity, at one concentration (the size of the read-out at that concentration, not a potency): 82%
The estimate for compound 4 lay 22 percentage points above the measured number; the whole stated range lies above it.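

In this assay, putting hydrogen in place of methoxy on an aromatic carbon gave a number 23 percentage points lower from compound 3 to compound 4 (beyond the scatter), and this step does not match the one seen for the same change on the other core: the same change on two cores in this assay, a number 4 percentage points higher (within the scatter) from compound 2 to compound 1 and a number 23 percentage points lower (beyond the scatter) from compound 3 to compound 4, 27 percentage points apart, beyond the scatter of two such steps In this small series, then, the step measured on one core was not a reliable guide to the step on the other, and the same exchange of methoxy for hydrogen could leave the read-out within the scatter on one core and move it beyond the scatter on another. Within the data shown here, this rests on only two pairs read at a single concentration, so it shows neither why the two steps differ nor which structural difference between the cores matters, and it says nothing about potency or about how the change would behave on any further core.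

The compounds shown leave open how the read-out responds when the methoxy group gives way to something other than hydrogen, such as a fluorine atom, an ethoxy group or a carboxylic acid. They also leave open whether taking away a methoxy group from another place on these rings would give a step of similar size.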